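Quinazoline series: amide-linked methylpiperazine in place of the amine chain

The compounds below may be only part of what the source reports. "The series", "measured", "known", "first", "only" and "open" are said of these compounds alone.

Compound 1 `CN(C)CCNc1nc(Nc2ccc(F)cc2)nc2ccccc12` and compound 2 `Fc1ccc(Nc2nc(NCCN3CCCC3)c3ccccc3n2)cc1` share one core and differ only in the amine at the chain end. In an ADME assay on HepG2 cells (Homo sapiens) for inhibition, with a stated time of 48 h (a lower number here means that less compound is needed, a higher number that more compound is needed for the effect), compound 1 gives 27900 nM, and compound 2 gives 26500 nM. Compound 2 stands alongside compound 1, the two numbers sitting within the scatter of each other, the step of a 1.1-fold lower number from compound 1 to compound 2 (0.02 log units; within the scatter) being flat. Compound 3 `CN1CCN(C(=O)CNc2nc(Nc3ccc(F)cc3)nc3ccccc23)CC1` is not yet measured; the change is (4-methylpiperazin-1-yl)carbonyl in place of (pyrrolidin-1-yl)methyl on a saturated chain carbon bound to a nitrogen on an aromatic ring. Among the measured compounds shown here, the only step that bears on it is the exchange of one saturated amine for another at the chain end, and that gave a 1.1-fold lower number from compound 1 to compound 2 (0.02 log units; within the scatter). The present change is larger, adding a carbonyl and a second ring nitrogen, but nothing measured here points in either direction. For compound 3 the expected step is a 1.2-fold higher number from compound 2 to compound 3 (0.08 log units; within the scatter), that is, none beyond the scatter. Compound 3 is therefore estimated at 32000 nM, with a range of 11000 nM to 95000 nM in this assay.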

Compound 3, half-maximal effective concentration: 30400 nM
The estimate for compound 3 lay 1.1-fold (0.02 log units) above the measured number; low and high end bracket the measured number.
By their numbers in this assay, from the lowest: compounds 2, 1 and 3 (each within the scatter of the next).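

In this assay the steps of a 1.1-fold higher number from compound 2 to compound 3 (0.06 log units; within the scatter) and a 1.1-fold higher number from compound 1 to compound 3 (0.04 log units; within the scatter) both lie within the scatter. Among the compounds shown here, the earlier pair compared only (pyrrolidin-1-yl)methyl with (dimethylamino)methyl, whereas (4-methylpiperazin-1-yl)carbonyl brings a carbonyl and a six-membered non-aromatic ring with 2 hetero atoms to the saturated chain carbon bound to a nitrogen on an aromatic ring, and still no step goes beyond the scatter. No supporting data are available to explain this flat result.

Going by these compounds, whether a carboxylic acid or a longer chain at this place would give a step beyond the scatter remains open. Also open, on these data alone, is how the flat step divides between the carbonyl and the ring, which a (4-methylpiperazin-1-yl)methyl group at this place would help to separate.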